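The source may hold more compounds than are shown below. What is called first, only, known or untested is meant among the compounds shown, and "the series" means these compounds.

Compound 1, `CC1(c2ccccc2)CC(=O)N(CC(=O)N2CCOCC2)C1=O`, gives 300 mg/kg in a functional assay on the whole organism (strain CD-1) with Mus musculus as the target, with a stated time of 0.5 h; on this read-out lower numbers stand for an effect already at smaller amounts and higher numbers for an effect only at larger amounts of compound.
Compound 2, `CC1(c2ccccc2)CC(=O)N(CC(=O)N2CCN(c3ccc(F)cc3)CC2)C1=O`, gives "not active" (no number reported) in this assay.
Compound 3, `CC1(c2ccccc2)CC(=O)N(CC(=O)N2CCN(c3ccccc3F)CC2)C1=O`, gives 100 mg/kg in this assay.

Compound 2 stands apart from the other two in this assay: for it no single number is given, only "not active" (no number reported), whereas compound 1 and compound 3 each show a dose at which an effect appears. Compound 4, `COc1cccc(N2CCN(C(=O)CN3C(=O)CC(C)(c4ccccc4)C3=O)CC2)c1`, has not yet been measured. It differs from compound 2 in one place: 3-methoxyphenyl in place of 4-fluorophenyl on an amine nitrogen in a ring. Among the measured compounds shown here, no measured pair of compounds shows this change, so the size and direction of the step cannot be read from the data, and compound 2 itself offers no number to step from. The expectation for compound 4 therefore leans on compound 1 and compound 3. Compound 4 is expected to give about 300 mg/kg in this assay, within 100 mg/kg to 1000 mg/kg, with a real chance that it too is reported only as not active.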

Compound 4, minimum effective dose: 100 mg/kg
Compound 4: middle estimate off by 3.0-fold (0.48 log units), on the high side; the range from low to high includes it.
By their numbers in this assay, from the lowest: compounds 3 and 4 (each within the scatter of the next); then compound 1.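

In this assay, the piperazine-free wording aside, a group on this amine nitrogen in a ring need not leave the compound without a dose: compound 2 gives "not active" (no number reported), while compound 4, with 3-methoxyphenyl in place of 4-fluorophenyl, gives 100 mg/kg. That step cannot be read as a size, since one side has no number. Replacing 2-fluorophenyl with 3-methoxyphenyl gives no change at the digits printed from compound 3 to compound 4 (within the scatter), so two different groups here read alike. No measurement given explains this. From the compounds shown here alone, whether 4-methoxyphenyl would read like compound 2 or like compound 4 stays open, as does the reading for an unsubstituted phenyl.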